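Dropping the phenoxy group from compound 1

The compounds below may be only part of what the source reports. "The series", "measured", "known", "first", "only" and "open" are said of these compounds alone.

Going by the values given here, compound 1 `N#Cc1ccc(-n2ccc3ccncc32)cc1Oc1ccccc1` gives 97% in an assay on isolated protein for inhibition of Aromatase (Homo sapiens), read by fluorescence, tested at 1 uM (a lower number here means less inhibition, a higher number more inhibition at the concentration tested (going by the name of the read-out)), the highest of the three numbers measured so far. Compound 3 `Cc1cc(-n2ccc3ccncc32)ccc1Cl` gives 96%, a number within the scatter of compound 1; compound 2 `N#Cc1ccc(Oc2cccnc2)cc1F` gives 15%, far beyond the scatter below compound 1. Compound 4 `N#Cc1ccc(-n2ccc3ccncc32)cc1` is not yet measured. Its change from compound 1 is hydrogen in place of phenoxy on an aromatic carbon, on the aromatic carbon ortho to the cyano group. Among the compounds with values here, no measured pair shows this change. Since compound 3, which carries no phenoxy group, gives 96%, only a modest downward step, if any beyond the scatter, is expected: a number 7 percentage points lower from compound 1 to compound 4 (within the scatter). Compound 4 is therefore estimated at 90%, in a range from 70% to 98%.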

Compound 4, a percentage reported as inhibition, at one concentration (the size of the read-out at that concentration, not a potency): 94%
The estimate for compound 4 lay 4 percentage points below the measured number; low and high end bracket the measured number.
By their numbers in this assay, from the lowest: compound 2; then compounds 4, 3 and 1 (each within the scatter of the next).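

In this assay, going by these compounds alone, hydrogen in place of phenoxy on the aromatic carbon ortho to the cyano group gives a number 3 percentage points lower from compound 1 to compound 4 (within the scatter) in the first direct pair for this change. Within this pair, the phenoxy group is therefore not needed to keep the number high at the concentration tested. No evidence bears on the reason for this result.

On these data alone, whether methoxy, an amine or a carboxylic acid on this carbon would keep the number high stays open. So does whether compound 1 and compound 4 would separate at a lower concentration.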